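Aryl replacements on the benzylamine of a cyclopentyl-purine series

The source may report more compounds than this note shows. Statements on the series, on what has been measured and on what is new or still open speak of the compounds shown alone.

Measured so far:
Compound 1 `NC1CCC(Nc2nc(NCc3ccc(Br)cc3)c3ncn(C4CCCC4)c3n2)CC1`: 1480 nM
Compound 2 `COc1ccccc1-c1ccc(CNc2nc(NC3CCC(N)CC3)nc3c2ncn3C2CCCC2)cc1`: 545 nM
Compound 3 `NC1CCC(Nc2nc(NCc3ccc(-c4ccsc4)cc3)c3ncn(C4CCCC4)c3n2)CC1`: 570 nM

All three share one core and differ only in the group on the benzylic ring. In a functional assay on G-361 cells (Homo sapiens) for inhibition, with a stated time of 72 h (a lower number here means a stronger inhibitor, a higher number a weaker inhibitor), compound 3 sits within the scatter of compound 2, the gap being a 1.0-fold higher number from compound 2 to compound 3 (0.02 log units; within the scatter), and apart from compound 1, which it beats by a 2.6-fold lower number from compound 1 to compound 3 (0.41 log units; beyond the scatter); the parallel step a 2.7-fold lower number from compound 1 to compound 2 (0.43 log units; beyond the scatter) is of the same size. Compound 4 `NC1CCC(Nc2nc(NCc3ccc(-c4ccsc4)nc3)c3ncn(C4CCCC4)c3n2)CC1` carries 6-(thiophen-3-yl)pyridin-3-yl in place of 4-(thiophen-3-yl)phenyl on a saturated chain carbon bound to a nitrogen on an aromatic ring. Going by the values given here, no measured step exchanges a ring carbon for a ring nitrogen, so none bears directly on this change; the known steps concern only what replaces the bromo. The expected step of a 1.1-fold higher number from compound 3 to compound 4 (0.02 log units; within the scatter) is therefore none beyond the scatter. For compound 4 the estimate in this assay is 600 nM, between 250 nM and 1500 nM.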

Compound 4, half-maximal inhibitory concentration: 272 nM
Beside the measured number, compound 4's estimate is 2.2-fold (0.34 log units) above it; low and high end bracket the measured number.
By their numbers in this assay, from the lowest: compounds 4, 2 and 3 (each within the scatter of the next, the first and the last beyond it); then compound 1.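

In this assay, exchanging a ring carbon for a ring nitrogen under the thiophen-3-yl group gives a step beyond the scatter, a 2.1-fold lower number from compound 3 to compound 4 (0.32 log units; beyond the scatter). Earlier steps changed only what replaces the bromo, whereas this one shows that the ring carrying the thiophen-3-yl group also affects the number, and the full replacement of 4-bromophenyl amounts to a 5.4-fold lower number from compound 1 to compound 4 (0.74 log units; beyond the scatter). Nothing measured here accounts for either step.

On these data alone, whether the same ring nitrogen has a like effect with 2-methoxyphenyl in place of thiophen-3-yl remains open. So does the effect of an amine or a carboxylic acid on that six-membered ring.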